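Aryl swap at the ring carbon: compound 3 to compound 4

A few compounds are considered here, and "the series" means these few. Any claim that something is new, unique, unknown or untested is made for them only; others in the source may bear on it.

Compound 3 `COc1cc(N2C(N)=C(C#N)C(/C=C/c3ccccc3)C3=C2CC(C)(C)CC3=O)cc(OC)c1OC` gives 30% in a functional assay on Ehrlich cells (Mus musculus) for cytotoxicity, tested at 50 ug/mL; a lower number here means a weaker effect, a higher number a stronger effect of the compound at the concentration tested. Among the three measured compounds this places compound 3 second highest: compound 1 `COc1cc(N2C(N)=C(C#N)C(c3ccc([N+](=O)[O-])cc3)C3=C2CC(C)(C)CC3=O)cc(OC)c1OC` gives 70% in this assay, while compound 2 `COc1ccc(C2C(C#N)=C(N)N(c3cc(OC)c(OC)c(OC)c3)C3=C2C(=O)CC(C)(C)C3)cc1` gives 11% in this assay. Among the compounds with values here, two steps touch the same saturated ring carbon that is changed next: a number 40 percentage points lower from compound 1 to compound 3 (beyond the scatter) and a number 19 percentage points higher from compound 2 to compound 3 (beyond the scatter). The remaining step, a number 59 percentage points lower from compound 1 to compound 2 (beyond the scatter), concerns a group on an aromatic carbon and bears less directly on the present change.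

Compound 4 `COc1cc(N2C(N)=C(C#N)C(c3c(OC)ccc4ccccc34)C3=C2CC(C)(C)CC3=O)cc(OC)c1OC` is not yet measured. It differs from compound 3 by 2-methoxynaphthalen-1-yl in place of 2-phenylethenyl on a saturated ring carbon. The entering group is aromatic and carries a methoxy, which recalls compound 2 with 11% in this assay. Because a number 19 percentage points higher from compound 2 to compound 3 (beyond the scatter) ran upward when such a group left this carbon, a downward step is expected on its return. Compound 4 is therefore expected to show a number 10 percentage points lower from compound 3 to compound 4 (within the scatter). Compound 4 is estimated at 20% in this assay, with a range from 5% to 45%.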

Compound 4, a percentage reported as activity, at one concentration (the size of the read-out at that concentration, not a potency): 10%
The estimate for compound 4 lay 10 percentage points above the measured number; measured number inside the range.
By their numbers in this assay, from the lowest: compounds 4 and 2 (each within the scatter of the next); then compound 3; then compound 1.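

Placing 2-methoxynaphthalen-1-yl on the saturated ring carbon in place of 2-phenylethenyl gives a number 20 percentage points lower from compound 3 to compound 4 (beyond the scatter) in this assay, so a second methoxy-bearing aryl group now sits at the low end of the series. Against the 4-methoxyphenyl group the exchange gives a number 1 percentage points lower from compound 2 to compound 4 (within the scatter), so the added aromatic ring makes no readable difference at this carbon, while the exchange against 4-nitrophenyl gives a number 60 percentage points lower from compound 1 to compound 4 (beyond the scatter), leaving compound 1 alone at the top of the four. Nothing available accounts for these differences.

The compounds shown leave open whether the methoxy or the aryl ring itself goes with the low read-out, which a plain naphthalen-1-yl group at this carbon would separate. Also open, as far as these compounds go, is whether the read-out of compound 1 is specific to nitro or would persist with an amino or carboxylic acid group at the same place on the phenyl ring.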